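Moving a chlorine on the benzylamide ring of compound 3

The source may hold more compounds than are shown below. What is called first, only, known or untested is meant among the compounds shown, and "the series" means these compounds.

Measured so far in an assay on brain for inhibition of Fatty-acid amide hydrolase 1 (Rattus norvegicus), read by scintillation counting, with a stated time of 10 min; a higher number here means a weaker inhibitor, a lower number a stronger inhibitor:
compound 1, `CC(C)Cc1ccc(C(C)C(=O)NCc2ccccc2)cc1`, 21000 nM
compound 2, `CC(C)Cc1ccc(C(C)C(=O)NCc2ccc(F)cc2)cc1`, 27000 nM
compound 3, `CC(C)Cc1ccc(C(C)C(=O)NCc2ccc(Cl)c(Cl)c2)cc1`, 36000 nM

Compound 3 has the highest number of the three in this assay, but its distance to the others is small: the step of a 1.7-fold higher number from compound 1 to compound 3 (0.23 log units; within the scatter) and the step of a 1.3-fold higher number from compound 2 to compound 3 (0.12 log units; within the scatter) both lie within the scatter, as does the step of a 1.3-fold higher number from compound 1 to compound 2 (0.11 log units; within the scatter). Taken together, the three measured compounds show that changing the substituents on the ring bound to the amide-type nitrogen has so far made no difference that can be trusted.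

Compound 4, `CC(C)Cc1ccc(C(C)C(=O)NCc2ccc(Cl)cc2Cl)cc1`, is the next step. Its change from compound 3 is 2,4-dichlorophenyl in place of 3,4-dichlorophenyl on a saturated chain carbon bound to an amide-type nitrogen. The two compounds hold the same atoms, joined differently; only the position of one chlorine on that ring moves.

The measured steps that bear on this are the three just named, each a change on the same ring and each within the scatter. They give no reason to expect a step beyond the scatter from compound 3 to compound 4; the estimated step is a 1.1-fold lower number from compound 3 to compound 4 (0.02 log units; within the scatter). For compound 4 in this assay the estimate is 34000 nM, within a range from 14000 nM to 80000 nM.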

Compound 4, half-maximal inhibitory concentration: 21000 nM
The estimate for compound 4 lay 1.6-fold (0.21 log units) above the measured number, within the range that was stated.
By their numbers in this assay, from the lowest: compounds 1, 4, 2 and 3 (each within the scatter of the next).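

In this assay, putting 2,4-dichlorophenyl in place of 3,4-dichlorophenyl on the saturated chain carbon bound to the amide-type nitrogen gives a 1.7-fold lower number from compound 3 to compound 4 (0.23 log units; within the scatter), so a change that only rearranges the same atoms on this ring also yields no difference that can be trusted. The other two new comparisons agree, with a 1.3-fold lower number from compound 2 to compound 4 (0.11 log units; within the scatter) and no change at the digits printed from compound 1 to compound 4 (within the scatter), which means that all four compounds now lie within the scatter of one another and that neither the number of halogens on this ring nor the place of one chlorine has yet separated them. No independent measurement is available to explain these numbers.

This ring carries only hydrogen, fluorine or chlorine in the compounds shown, so it remains open whether an amine or a carboxylic acid on the ring, or a longer chain between the ring and the amide-type nitrogen, would produce a step beyond the scatter. On these data alone, whether a change elsewhere in the shared core would do so also remains open.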